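A few compounds are considered here, and "the series" means these few. Any claim that something is new, unique, unknown or untested is made for them only; others in the source may bear on it.

Compound 1 `CCOC(=O)N1CCC(=NNC(=O)c2ccc([N+](=O)[O-])cc2)CC1`: 40200 nM
Compound 2 `O=C(NN=C1CC(c2ccccc2)NC(c2ccccc2)C1)c1ccc(F)cc1`: 56600 nM

In a functional assay for inhibition, read by spectrophotometry, with a stated time of 120 min (a lower number here means a stronger inhibitor, a higher number a weaker inhibitor), compound 2 gives 56600 nM, the higher of the two numbers, while compound 1 gives 40200 nM, a gap that lies within the scatter. Compound 3 `O=C(NN=C1CC(c2ccccc2)NC(c2ccccc2)C1)c1ccc([N+](=O)[O-])cc1` carries the change (nitro in place of fluoro on an aromatic carbon). Among the measured compounds shown here, no comparable step has been measured, so the expected step of a 1.3-fold lower number from compound 2 to compound 3 (0.13 log units; within the scatter) is small, not beyond the scatter. Compound 3 is therefore estimated at 42000 nM, within 15000 nM to 110000 nM, because compound 2 gives 56600 nM as the closest starting point.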

Compound 3, half-maximal inhibitory concentration: 45200 nM
Beside the measured number, compound 3's estimate is 1.1-fold (0.03 log units) below it, and the stated range covers the measured number.
By their numbers in this assay, from the lowest: compounds 1, 3 and 2 (each within the scatter of the next).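

In this assay, nitro in place of fluoro on this aromatic carbon, para to a large group, gives a 1.3-fold lower number from compound 2 to compound 3 (0.10 log units; within the scatter) and so leaves the number within the scatter, although the entering group is larger and adds hydrogen-bond acceptors. Compound 1 and compound 2 differ in more than one place, so they could not show this for any single position. No measurement at hand bears on the reason for this result. The compounds shown leave open whether an amine or a carboxylic acid on this aromatic carbon would shift the number beyond the scatter.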